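Methoxy to hydroxy on a pyrazole urea series

This account rests on a few compounds, and the source may have more. Where it says the series, first, only, none or still open, it means among the compounds named here.

Two measured compounds frame this step. Compound 2 `COc1cc(-c2nn(-c3cccc(NC(=O)Nc4cc(C(F)(F)F)cc(C(F)(F)F)c4)c3)cc2-c2ccncc2)ccc1Cl` gives the lower of the two numbers in a functional assay on OVCAR-5 cells (Homo sapiens) for inhibition, read by sulforhodamine B assay, with a stated time of 48 h (on this read-out lower numbers stand for stronger inhibition of growth and higher numbers for weaker inhibition of growth), at 937 nM, while compound 1 `O=C(Nc1cccc(-n2cc(-c3ccncc3)c(-c3ccc(Cl)c(O)c3)n2)c1)Nc1cccc(C(F)(F)F)c1` reaches only 13700 nM in this assay, a gap beyond the scatter. Compound 3 `O=C(Nc1cccc(-n2cc(-c3ccncc3)c(-c3ccc(Cl)c(O)c3)n2)c1)Nc1cc(C(F)(F)F)cc(C(F)(F)F)c1` is drawn from compound 2 by hydrogen in place of methyl on an oxygen on an aromatic ring. Among the measured compounds shown here, no measured pair shows this change on its own, so its size is uncertain; compound 1, which also carries the hydroxy, gives the weaker number, and a loss of some size is expected for the step of a 3.2-fold higher number from compound 2 to compound 3 (0.51 log units; beyond the scatter). Compound 3 is therefore estimated at 3000 nM, within 800 nM to 12000 nM.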

Compound 3, concentration for 50% growth inhibition: 875 nM
Compound 3: the middle estimate sits 3.4-fold (0.54 log units) above what was measured; low and high end bracket the measured number.
By their numbers in this assay, from the lowest: compounds 3 and 2 (each within the scatter of the next); then compound 1.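

In this assay methoxy to hydroxy leaves the number within the scatter (a 1.1-fold lower number from compound 2 to compound 3 (0.03 log units; within the scatter)), so on this series the oxygen on the aromatic ring carries either hydrogen or methyl without a measurable difference. The large step instead comes with trifluoromethyl in place of hydrogen on an aromatic carbon (a 16-fold lower number from compound 1 to compound 3 (1.19 log units; beyond the scatter)), and the hydroxy alone does not account for the weak number of compound 1. Nothing given here explains either step. As far as these compounds go, whether an ethoxy or an amine at this position would hold the number stays open, as does whether the trifluoromethyl step has the same size with the methoxy in place.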